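Carbamate ester swap on a fluorocytosine nucleoside scaffold

The source may report more compounds than this note shows. Statements on the series, on what has been measured and on what is new or still open speak of the compounds shown alone.

Of the compounds shown here, three have been measured in a functional assay on HeLa cells (Homo sapiens) for cytotoxicity, read by MTT assay, with a stated time of 3 days; a lower number here means a stronger inhibitor, a higher number a weaker inhibitor. Compound 1, `C[C@H]1O[C@@H](n2cc(F)c(NC(=O)Oc3ccc([N+](=O)[O-])cc3)nc2=O)[C@@H]2OC(=O)O[C@@H]21`, gives 30 ug/mL in this assay. Compound 2, `C[C@H]1O[C@@H](n2cc(F)c(NC(=O)Oc3ccc([N+](=O)[O-])cc3)nc2=O)[C@H](O)[C@@H]1O`, differs from it by a group of 8 heavy atoms (5 carbon, 3 oxygen; one five-membered non-aromatic ring with 1 hetero atom) in place of a group of 10 heavy atoms (6 carbon, 4 oxygen; one five-membered non-aromatic ring with 1 hetero atom, one five-membered non-aromatic ring with 2 hetero atoms), on an aromatic nitrogen and gives 10 ug/mL in this assay, a step described by a 3.0-fold lower number from compound 1 to compound 2 (0.48 log units; beyond the scatter). Compound 3, `CCC(C)COC(=O)Nc1nc(=O)n([C@@H]2O[C@H](C)[C@H]3OC(=O)O[C@H]32)cc1F`, carries the change 2-methylbutyl in place of 4-nitrophenyl on an oxygen next to a carbonyl group on the core of compound 1. In this assay compound 3 gives 180 ug/mL; that step reads a 6.0-fold higher number from compound 1 to compound 3 (0.78 log units; beyond the scatter). Of the three, compound 2 has the lowest number, with compound 1 nearest and compound 3 furthest from it.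

Compound 4, `CCC(C)COC(=O)Nc1nc(=O)n([C@@H]2O[C@H](C)[C@@H](O)[C@H]2O)cc1F`, has not been measured. It relates to compound 2 as compound 3 relates to compound 1: the change is 2-methylbutyl in place of 4-nitrophenyl on an oxygen next to a carbonyl group, and the two cores differ by a group of 8 heavy atoms (5 carbon, 3 oxygen; one five-membered non-aromatic ring with 1 hetero atom) in place of a group of 10 heavy atoms (6 carbon, 4 oxygen; one five-membered non-aromatic ring with 1 hetero atom, one five-membered non-aromatic ring with 2 hetero atoms), on an aromatic nitrogen. The change on compound 1 produced a 6.0-fold higher number from compound 1 to compound 3 (0.78 log units; beyond the scatter); among the compounds shown this change occurs twice, and the second instance is the one now awaited. Since the place of the change is the same in both pairs, the same change is assumed to act in the same direction on compound 2. The step expected from compound 2 to compound 4 in this assay is therefore a 6.0-fold higher number from compound 2 to compound 4 (0.78 log units; beyond the scatter), resting on the measured step of a 6.0-fold higher number from compound 1 to compound 3 (0.78 log units; beyond the scatter). On that basis compound 4 is estimated at 60 ug/mL in this assay, with a plausible range from 25 ug/mL to 150 ug/mL.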

Compound 4, half-maximal inhibitory concentration: 90 ug/mL
For compound 4 the middle estimate is 1.5-fold (0.18 log units) below the measured one, and the stated range covers the measured number.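

In this assay, putting 2-methylbutyl in place of 4-nitrophenyl on an oxygen next to a carbonyl group again moves the number upward on the second core, giving a 9.0-fold higher number from compound 2 to compound 4 (0.95 log units; beyond the scatter), so the direction seen on the core of compound 1 is repeated. Among the compounds shown here, the size of the step also carries over, since the two instances cannot be told apart in this assay: the same change on two cores in this assay, a 6.0-fold higher number (0.78 log units; beyond the scatter) from compound 1 to compound 3 and a 9.0-fold higher number (0.95 log units; beyond the scatter) from compound 2 to compound 4, 1.5-fold (0.18 log units) apart, within the scatter of two such steps This supports treating the change as transferable between these two cores, but it rests on only two matched pairs, a single pair of groups and a single assay, so it does not show that the same step would hold on any other core, nor does it explain why the change has this effect.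

The compounds shown have only 4-nitrophenyl and 2-methylbutyl on that oxygen, so they cannot tell whether the step follows from losing the nitro group, losing the aromatic ring or gaining the branched chain. On these data alone, a plain phenyl, a benzyl group, a straight pentyl chain or a longer alkyl chain in the same place would be needed to separate these readings, and how any of them would behave on either core remains open.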